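Methyl on the Ring Nitrogen: Forecast for Compound 4

A few compounds are considered here, and "the series" means these few. Any claim that something is new, unique, unknown or untested is made for them only; others in the source may bear on it.

Of the compounds shown here, three have been measured in a physicochemical assay for lipophilicity; a higher number here means a more lipophilic compound, a lower number a more polar compound. Compound 3 `NC(=O)C1CCN(C(=O)c2c[nH]c3ccccc23)CC1` gives -0.2. For the measured compounds named here, compound 1 `Cn1cc(C(=O)N2CCC(C(N)=O)CC2)c2ccccc21` gives 0.4, and the only change between the two is methyl in place of hydrogen on an aromatic nitrogen, which made a step of a number 0.60 log units higher from compound 3 to compound 1 (beyond the scatter). Compound 2 `O=C(Cn1ccccc1=O)Nc1cc2ccccc2[nH]1` gives 0.4, a value that lies within the scatter of compound 1 and is, together with it, the highest of the three. How the core of compound 2 differs from the core of compound 3 is not broken down here; their values simply show compound 2 lying higher than compound 3 by a margin beyond the scatter.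

Compound 4 `Cn1c(NC(=O)Cn2ccccc2=O)cc2ccccc21` has not yet been measured in this assay. It differs from compound 2 by methyl in place of hydrogen on an aromatic nitrogen. Going by the values given here, this is the same kind of change as the one from compound 3 to compound 1, but not the same: in compound 1 the methyl sits two ring bonds from the ring atom that bears a large group, whereas in compound 4 it sits next to the ring atom that bears a large group. Among the compounds shown the change occurs twice, and only the pair from compound 3 to compound 1 carries a measurement. The expected step of a number 0.60 log units higher from compound 2 to compound 4 (beyond the scatter) rests on that measured step a number 0.60 log units higher from compound 3 to compound 1 (beyond the scatter), with a wider range allowed for the different place. Compound 4 is therefore estimated at 1, expected to lie between 0.6 and 1.4.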

Compound 4, partition coefficient: 1.1
Compound 4: the middle estimate sits 0.10 log units below what was measured, and the stated range covers the measured number.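

Across the two cores, this assay moved the same way for the one change: methyl in place of hydrogen on an aromatic nitrogen gave a number 0.70 log units higher from compound 2 to compound 4 (beyond the scatter) and, on the other core, a number 0.60 log units higher from compound 3 to compound 1 (beyond the scatter) as well, both in the direction of a higher number. This shows that the change carried from one core to the other in this series, including to compound 4, where the methyl sits next to the ring atom that bears a large group. It rests on only two pairs, however, so it sets no general rule for other cores, and nothing among the data shown explains the step on either core or tells what lies behind the result.

The compounds shown hold only methyl at this nitrogen, so it stays open whether ethyl, a longer chain, or a chain ending in an amine or a carboxylic acid would move the number the same way on either core. Also open, from the compounds shown here alone, is whether the step seen in these two pairs would appear on a third core, or whether it would hold once other parts of compound 4 are changed.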